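The source may report more compounds than this note shows. Statements on the series, on what has been measured and on what is new or still open speak of the compounds shown alone.

Measured in an ADME assay on BJ cells (Homo sapiens) for cytotoxicity, with a stated time of 72 h (a higher number here means that more compound is needed for the effect, a lower number that less compound is needed), for the series:
- compound 1 `Cc1cc(NC(=O)Nc2ccccc2OC(F)(F)F)c2ccccc2n1` gives > 25000 nM as a limit
- compound 2 `Cc1cc(NC(=O)Nc2ccccc2N)c2ccccc2n1` gives > 25000 nM as a limit
- compound 3 `Cc1cc(NC(=O)Nc2ccccc2C(N)=O)c2ccccc2n1` gives > 25000 nM as a limit

Compound 2 stands at > 25000 nM and this is a limit, not a number. The other two measured compounds also give only a limit, so no ranking can be drawn among the three.

The change under consideration leads to compound 4 `Cc1cc(NC(=O)Nc2ccc(O)cc2)c2ccccc2n1` and is 4-hydroxyphenyl in place of 2-aminophenyl on an amide-type nitrogen. For the measured compounds named here, no measured compound carries 4-hydroxyphenyl.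

Going by the values given here, three measured steps bear on this change. They are a step that the two limits leave unreadable from compound 1 to compound 2 and a step that the two limits leave unreadable from compound 1 to compound 3 and also a step that the two limits leave unreadable from compound 2 to compound 3 as the third. None of them has a readable size. The whole basis for expectation is the limit of > 25000 nM in this assay, at which 3 of the 3 values shown sit, and nothing more.

In this assay the expectation is therefore no step beyond the scatter, with no direction to be read. The expected step is a step that the limit leaves unreadable from compound 2 to compound 4 on that basis. Most likely the result for compound 4 will again be reported only as a limit. If a number is returned, for compound 4 the estimate is 30000 nM as the expected value. The expected range for that estimate runs from 12000 nM to 60000 nM in the same assay.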

Compound 4, half-maximal effective concentration: > 25000 nM
Compound 4: no number, only a limit (the forecaster's own chance of this, stated with the estimate: 80%); the middle value does not contradict the limit.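

Compound 4 gives > 25000 nM in this assay, which is a limit and not a number. For the compounds shown here, compound 2 also stands only at a limit, so no step between compound 2 and compound 4 can be read. The compounds shown leave open whether any change on the shared core would give a readable value in this assay.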